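Swapping the piperazine substituent: from compound 1 to compound 3

A few compounds are considered here, and "the series" means these few. Any claim that something is new, unique, unknown or untested is made for them only; others in the source may bear on it.

Measured so far:
compound 1, `COc1ccc(N2CCN(C(=S)SCc3ccc(C(=O)Nc4ccccc4N)cc3)CC2)cc1`, 35.9%
compound 2, `Nc1ccccc1NC(=O)c1ccc(CSC(=S)N2CCCc3ccccc32)cc1`, 81.5%

Both compounds were tested in a functional assay on A-375 cells (Homo sapiens) for antiproliferative activity, read by CCK-8 assay, with a stated time of 72 h, tested at 8 uM; on this read-out higher numbers stand for a stronger effect at the one concentration tested and lower numbers for a weaker effect. On this read-out compound 1 gives 35.9%, the lowest of the two numbers shown. Compound 2 gives 81.5%, a number that lies beyond the usual scatter above compound 1. The two compounds differ in more than one place, so their gap is simply what the two values show.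

Compound 3, `Nc1ccccc1NC(=O)c1ccc(CSC(=S)N2CCN(Cc3ccccc3)CC2)cc1`, has not yet been measured in this assay . It differs from compound 1 in one place: benzyl in place of 4-methoxyphenyl on an amine nitrogen in a ring. For the measured compounds named here, no step between measured compounds isolates this kind of change, so the expectation rests on little. A small rise is expected for this assay , with the step from compound 1 to compound 3 estimated at a number 12.1 percentage points higher from compound 1 to compound 3 (beyond the scatter). Compound 3 is therefore expected to reach about 48%, within a range from 25% to 72%.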

Compound 3, a percentage reported as inhibition, at one concentration (the size of the read-out at that concentration, not a potency): 29.3%
For compound 3 the middle estimate is 18.7 percentage points above the measured one, and the stated range covers the measured number.
By their numbers in this assay, from the lowest: compounds 3 and 1 (each within the scatter of the next); then compound 2.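

In this assay, putting benzyl in place of 4-methoxyphenyl on this amine nitrogen gives a number 6.6 percentage points lower from compound 1 to compound 3 (within the scatter), so this single change does not separate the two compounds on this read-out. Both groups carry one six-membered aromatic ring of carbon only, and the swap also removes the one hydrogen-bond acceptor counted in the group that leaves, yet the result stays within the usual scatter. No measurement at hand explains why the two compounds read alike.

Going by these compounds, it remains open how the read-out would respond to a group on this nitrogen with no aromatic ring, such as methyl or acetyl. A longer link to the aromatic ring, as in 2-phenylethyl, is equally untested by the compounds shown here.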